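Amide nitrogen variation in the dimethoxy series; a branched alkyl

The source may report more compounds than this note shows. Statements on the series, on what has been measured and on what is new or still open speak of the compounds shown alone.

Three amides on the shared core have numbers in a functional assay on the whole organism (strain Wistar) for inhibition, with Rattus norvegicus as the target, read by paw edema, with stated times of 60 min and 3 h, at a dose of 100 mg/kg by the oral route; on this read-out lower numbers stand for less inhibition and higher numbers for more inhibition at the one dose given (going by the name of the read-out). Compound 1 `COc1cc2c(cc1OC)C(CC(=O)N(C)C)CC2` gives 34.8%, compound 2 `CCN(CC)C(=O)CC1CCc2cc(OC)c(OC)cc21` gives 37.7%, and compound 3 `CCCCNC(=O)CC1CCc2cc(OC)c(OC)cc21` gives 27.5%. Compound 3 stands lowest of the three, though only the gap to compound 2, a number 10.2 percentage points lower from compound 2 to compound 3 (beyond the scatter), exceeds the scatter; the gap to compound 1, a number 7.3 percentage points lower from compound 1 to compound 3 (within the scatter), does not. Compound 4 `COc1cc2c(cc1OC)C(CC(=O)NC(C)(C)C)CC2` differs from compound 3 by tert-butyl in place of butyl on an amide-type nitrogen. All measured steps at this nitrogen, including a number 2.9 percentage points higher from compound 1 to compound 2 (within the scatter), stay small, and none involves tert-butyl, so no step beyond the scatter is expected in this assay . The estimate for compound 4 is 30% (range 17% to 43%), a step of a number 2.5 percentage points higher from compound 3 to compound 4 (within the scatter) from compound 3.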

Compound 4, a percentage reported as inhibition, in the whole organism at one dose (the size of the read-out at that dose, not a potency): 33.3%
For compound 4 the middle estimate is 3.3 percentage points below the measured one; the measured number falls inside the stated range.
By their numbers in this assay, from the lowest: compounds 3, 4, 1 and 2 (each within the scatter of the next, the first and the last beyond it).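

In this assay, tert-butyl in place of butyl on the amide-type nitrogen gives a step within the scatter (a number 5.8 percentage points higher from compound 3 to compound 4 (within the scatter)). For the compounds shown here, the tert-butyl amide also lies within the scatter of the two dialkyl amides (a number 4.4 percentage points lower from compound 2 to compound 4 (within the scatter); a number 1.5 percentage points lower from compound 1 to compound 4 (within the scatter)), so among the steps to compound 2 only the one to the butyl amide, compound 3, lies beyond it. Nothing available accounts for these numbers. Still open, on these data alone, is how a cyclohexyl or benzyl group on this nitrogen would read, and how a piperidine amide or the unsubstituted amide would compare.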